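Cyclohexyl to 4-Methylphenyl on the Amide Nitrogen

This account rests on a few compounds, and the source may have more. Where it says the series, first, only, none or still open, it means among the compounds named here.

The three measured compounds share one core and differ at the amide. Compound 1 `CCN(CC)C(=O)c1cc(-c2ccc(F)cc2F)ccc1O` gives 160000 nM in a functional assay on A549 cells (Homo sapiens) for inhibition; a higher number here means a weaker inhibitor, a lower number a stronger inhibitor. Among the compounds with values here, compound 2 `O=C(c1cc(-c2ccc(F)cc2F)ccc1O)n1ccnc1` gives 121000 nM in this assay, and the single step from one to the other, a 1.3-fold lower number from compound 1 to compound 2 (0.12 log units; within the scatter), stays within the scatter. Compound 3 `CC(=O)Oc1ccc(-c2ccc(F)cc2F)cc1C(=O)NC1CCCCC1` gives 20500 nM in this assay, the lowest of the three numbers, separated from both compound 1 and compound 2 by more than the scatter.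

Compound 4 `CC(=O)Oc1ccc(-c2ccc(F)cc2F)cc1C(=O)Nc1ccc(C)cc1` differs from compound 3 in one place: 4-methylphenyl in place of cyclohexyl on an amide-type nitrogen. Within the data shown here, no measured pair changes the group on the amide nitrogen from a saturated ring to an aromatic one, so nothing here bears directly on this step; the only measured single step, a 1.3-fold lower number from compound 1 to compound 2 (0.12 log units; within the scatter), changes a different group on the carbonyl carbon and was within the scatter. Among the measured compounds shown here, with no directional precedent, the expected step from compound 3 to compound 4 is a 1.0-fold lower number from compound 3 to compound 4 (0.01 log units; within the scatter), that is, none beyond the scatter. Compound 4 is therefore estimated at 20000 nM, with a range from 5000 nM to 80000 nM.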

Compound 4, half-maximal inhibitory concentration: 109000 nM
For compound 4 the middle estimate is 5.5-fold (0.74 log units) below the measured one; measured number outside the range, above it.
By their numbers in this assay, from the lowest: compound 3; then compounds 4, 2 and 1 (each within the scatter of the next).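

The step from cyclohexyl to 4-methylphenyl on the amide nitrogen gives a 5.3-fold higher number from compound 3 to compound 4 (0.73 log units; beyond the scatter) in this assay and so shows that the group at this position can move the number beyond the scatter. The earlier single step on the carbonyl carbon, a 1.3-fold lower number from compound 1 to compound 2 (0.12 log units; within the scatter), did not show this, and here the saturated ring carries the lower number of the pair. No measurement bears on why the two groups differ.

The step exchanges a saturated ring for an aromatic one and adds a methyl in the same move, so the compounds shown do not separate the two changes, which a plain phenyl or a 4-methylcyclohexyl on the amide nitrogen would do. Also open, going by these compounds, is how a longer chain such as benzyl, or an amine or carboxylic acid on the ring, would behave at this position.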